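The source may hold more compounds than are shown below. What is called first, only, known or untested is meant among the compounds shown, and "the series" means these compounds.

Compound 1 `Cc1ccc(NC(=O)[C@H]2CN(C)C[C@@H]2c2ccc(/C=C/C(=O)Nc3ccccc3N)cc2)cc1` in an in vitro ADME assay on microsomes from liver (Mus musculus) for pharmacokinetics, read by LC-MS, with a stated time of 10 min, tested at 1 uM (on this read-out higher numbers stand for fast clearance and lower numbers for slow clearance), gives 62 mL/min/kg. Compound 2 `CN1C[C@H](C(=O)Nc2ccc(F)c(Br)c2)[C@@H](c2ccc(/C=C/C(=O)Nc3ccccc3N)cc2)C1` gives 43 mL/min/kg. Among the measured compounds shown here, the only step between them, a 1.4-fold lower number from compound 1 to compound 2 (0.16 log units; within the scatter), swaps the aryl group on the amide-type nitrogen while the rest of the shared core is kept, and it stays within the scatter; the two numbers therefore sit together, and compound 2 is not set apart from compound 1 on this read-out.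

Compound 3 `Cc1ccc(NC(=O)[C@H]2CN(C)C[C@@H]2c2ccc(/C=C/C(=O)Nc3ccccc3N)cc2)cn1` carries the change (6-methylpyridin-3-yl in place of 3-bromo-4-fluorophenyl on an amide-type nitrogen). For the measured compounds named here, the one measured step that bears on it, a 1.4-fold lower number from compound 1 to compound 2 (0.16 log units; within the scatter), is likewise a swap of the group on that same nitrogen and left the clearance number where it was. On that basis no step beyond the scatter is expected in this assay , and the estimate for compound 3 is 45 mL/min/kg within 25 mL/min/kg to 80 mL/min/kg. The step this estimate implies, a 1.0-fold higher number from compound 2 to compound 3 (0.02 log units; within the scatter), is expected to lie inside the usual scatter.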

Compound 3, clearance: 57 mL/min/kg
Compound 3: middle estimate off by 1.3-fold (0.10 log units), on the low side, and the stated range covers the measured number.
By their numbers in this assay, from the lowest: compounds 2, 3 and 1 (each within the scatter of the next).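

In this assay, the amide-type nitrogen now carries a third aryl group, and both new steps stay within the scatter (a 1.3-fold higher number from compound 2 to compound 3 (0.12 log units; within the scatter) and a 1.1-fold lower number from compound 1 to compound 3 (0.04 log units; within the scatter)). A ring with 1 hetero atom and 1 hydrogen-bond acceptor, 6-methylpyridin-3-yl, therefore does not set compound 3 apart from compound 1 with its 4-methylphenyl or from compound 2 with its 3-bromo-4-fluorophenyl, so at this position the read-out has not yet separated any of the three groups. No measurement bearing on the reason for this is available.

As far as these compounds go, all three groups are six-membered aromatic rings, so the effect of a cyclohexyl group, or of a chain ending in an amine or a carboxylic acid, on that nitrogen remains open. From the compounds shown here alone, whether a change elsewhere on the shared core would give a step beyond the scatter also remains open.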